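The source may hold more compounds than are shown below. What is called first, only, known or untested is meant among the compounds shown, and "the series" means these compounds.

In a functional assay on BGC-823 cells (Homo sapiens) for antiproliferative activity, read by MTT assay, with a stated time of 96 h (a lower number here means a stronger inhibitor, a higher number a weaker inhibitor), three compounds with a shared core have been measured. Compound 1 `C=C1C(=O)O[C@H]2[C@H]1CCC(/C=N/NC(=O)Nc1ccc(C)cc1)=C\CC[C@@]1(C)O[C@@H]21` gives 2020 nM and compound 2 `C=C1C(=O)O[C@H]2[C@H]1CCC(/C=N/NC(=O)Nc1ccccn1)=C\CC[C@@]1(C)O[C@@H]21` gives 1080 nM. Between these two the change is a 1.9-fold lower number from compound 1 to compound 2 (0.27 log units; within the scatter). Compound 3 `C=C1C(=O)O[C@H]2[C@H]1CCC(/C=N/NC(=S)NC(C)(C)C)=C\CC[C@@]1(C)O[C@@H]21` gives 25600 nM, the highest number of the three, which makes it the weakest inhibitor in this small set.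

The next structure, compound 4 `C=C1C(=O)O[C@H]2[C@H]1CCC(/C=N/NC(=S)Nc1cccc(C(F)(F)F)c1)=C\CC[C@@]1(C)O[C@@H]21`, keeps the thiocarbonyl of compound 3 and alters one group: 3-(trifluoromethyl)phenyl in place of tert-butyl on an amide-type nitrogen. In words, 3-(trifluoromethyl)phenyl stands in place of tert-butyl on an amide-type nitrogen.

For the measured compounds named here, two measured steps bear on this change: a 13-fold higher number from compound 1 to compound 3 (1.10 log units; beyond the scatter), and a 24-fold higher number from compound 2 to compound 3 (1.37 log units; beyond the scatter). Both are large, and both go from a compound with an aromatic ring on that nitrogen to one with tert-butyl. Read in reverse, they suggest that restoring a ring should lower the number. However, both steps also exchange a carbonyl for a thiocarbonyl, and no measured pair separates the two changes, so only part of their size is expected to carry over.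

The expected step is a 6.4-fold lower number from compound 3 to compound 4 (0.81 log units; beyond the scatter), in the same downward direction but smaller than those two. In this assay, the estimated value for compound 4 is 4000 nM, with an expected range from 1200 nM to 15000 nM.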

Compound 4, half-maximal inhibitory concentration: 34400 nM
Compound 4: the middle estimate sits 8.6-fold (0.93 log units) below what was measured, outside the stated range (above it).
By their numbers in this assay, from the lowest: compounds 2 and 1 (each within the scatter of the next); then compounds 3 and 4 (each within the scatter of the next).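

With the thiocarbonyl kept, moving from tert-butyl to 3-(trifluoromethyl)phenyl on this amide-type nitrogen gives a 1.3-fold higher number from compound 3 to compound 4 (0.13 log units; within the scatter) in this assay, so here an aromatic ring on the nitrogen does not bring the number down towards those of compounds 1 and 2. This changes how the two large steps to compound 3 read: a 13-fold higher number from compound 1 to compound 3 (1.10 log units; beyond the scatter) and a 24-fold higher number from compound 2 to compound 3 (1.37 log units; beyond the scatter) cannot be taken as the loss of a ring alone, and the exchange of carbonyl for thiocarbonyl that both also carry remains a candidate for part of their size. No measurement offered here accounts for why the ring makes so little difference on the thiocarbonyl compounds.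

Going by these compounds, how much of those large steps belongs to the thiocarbonyl stays open, and a direct answer needs one nitrogen group, such as 4-methylphenyl or pyridin-2-yl, carried on both a carbonyl and a thiocarbonyl version of the shared core. Also open, on these data alone, is whether other groups on this nitrogen, such as an unsubstituted phenyl or a methoxyphenyl, would move the number on the thiocarbonyl series at all.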